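The compounds below may be only part of what the source reports. "The series", "measured", "known", "first", "only" and "open" are said of these compounds alone.

In a functional assay on MCF7 cells (Homo sapiens) for antiproliferative activity, read by MTT assay, with a stated time of 72 h (a lower number here means a stronger inhibitor, a higher number a weaker inhibitor), compound 1 (`CCN(CC)CCNC(=O)c1ccc(C(CC)(CC)c2ccc(OCC(O)C(C)(C)C)c(C)c2)n1CC`) gives 1370 nM, compound 2 (`CCN(CC)CCCNC(=O)c1ccc(C(CC)(CC)c2ccc(C#CC(O)(CC)CC)c(C)c2)n1CC`) gives 17800 nM and compound 3 (`CCn1cc(C(CC)(CC)c2ccc(C#CC(O)(CC)CC)c(C)c2)cc1C(=O)NCCN(C)C`) gives 13400 nM. Compound 3 therefore lies within the scatter of compound 2, while compound 1 has a lower number by a margin beyond the scatter.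

The next compound to be considered is compound 4 (`CCn1cc(C(CC)(CC)c2ccc(C#CC(O)(CC)CC)c(C)c2)cc1C(=O)N[C@@H](C(=O)O)C(C)C`). It keeps the rest of compound 3 but carries 1-carboxy-2-methylpropyl in place of 2-(dimethylamino)ethyl on an amide-type nitrogen.

Among the compounds with values here, no two measured compounds differ in one place only, and none of them carries the entering group, so the data offer no direct measure of this change. The expectation therefore starts from compound 3 at 13400 nM and assumes no shift beyond the scatter in this assay, with at most a slight move towards a higher number. An estimated 1.1-fold higher number from compound 3 to compound 4 (0.05 log units; within the scatter) would stay within the scatter. The range is kept wide on both sides, since compound 1 at 1370 nM shows how far apart numbers in this small set can lie. For compound 4 the expected value is 15000 nM, with an estimated range from 3000 nM to 60000 nM.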

Compound 4, half-maximal inhibitory concentration: 18000 nM
Compound 4: middle estimate off by 1.2-fold (0.08 log units), on the low side; the range from low to high includes it.
By their numbers in this assay, from the lowest: compound 1; then compounds 3, 2 and 4 (each within the scatter of the next).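

In this assay, within the data shown here, putting 1-carboxy-2-methylpropyl in place of 2-(dimethylamino)ethyl on the amide-type nitrogen gives a 1.3-fold higher number from compound 3 to compound 4 (0.13 log units; within the scatter) and is the first single-place change that can be read in this set. For this pair, a chain ending in a dimethylamino group and a branched chain carrying a carboxy group and a defined stereocentre give numbers within the scatter of each other, so the exchange leaves no measurable mark on the antiproliferative read-out at this position. No measurement shown here offers an explanation for this result.

The compounds shown leave open whether a methyl ester in place of the carboxylic acid, the opposite configuration at the stereocentre, or a longer chain ending in a piperidine would also stay within the scatter of compound 3. They also leave open which structural feature separates compound 1, at 1370 nM in this assay, from the others, since it differs from each of them in more than one place and no single change can be read from it.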